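A Single Fluoro Swap on a Short-Lived Compound

The compounds below may be only part of what the source reports. "The series", "measured", "known", "first", "only" and "open" are said of these compounds alone.

In an ADME assay on microsomes (Homo sapiens) for metabolic stability (a higher number here means that the compound lasts longer, a lower number that the compound disappears faster), compound 1 `Cc1ccc(C2CC=NN2C(=O)C(C)(C)C)cc1` gives 0.367 h. Among the compounds with values here, only one other compound has a measured number so far: compound 2 `O=C(c1ccccc1)N1CCC(C(=O)N2N=CCC2c2ccccc2)CC1` gives 1.72 h. Compound 1 therefore holds the lower of the two numbers, and the gap between them lies beyond the usual scatter of repeated measurements. These two compounds differ in more than one place, so their gap cannot show what a single small edit would do.

The next compound, compound 3 `Cc1ccc(C2CC=NN2C(=O)C(C)(C)C)cc1F`, changes compound 1 in just one place: fluoro in place of hydrogen on an aromatic carbon. A fluoro takes the place of hydrogen on an aromatic carbon, ortho to a methyl group, and the rest of the structure stays the same. Within the data shown here, no pair of measured compounds shows the effect of such a swap in this assay, so this expectation is a cautious one, resting only on how small the edit is. The expected result is a 1.2-fold higher number from compound 1 to compound 3 (0.09 log units; within the scatter), a slight rise that stays within the scatter. Compound 3 is expected at 0.45 h, with an estimated range from 0.22 h to 0.95 h.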

Compound 3, half-life: 0.267 h
For compound 3 the middle estimate is 1.7-fold (0.23 log units) above the measured one; the measured number falls inside the stated range.
By their numbers in this assay, from the lowest: compounds 3 and 1 (each within the scatter of the next); then compound 2.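

In this assay the swap of hydrogen for fluoro on this aromatic carbon, ortho to a methyl group and meta to a large group, gives a 1.4-fold lower number from compound 1 to compound 3 (0.14 log units; within the scatter) and so stays within the scatter. Within the data shown here, this is the first step in the set that changes only one place, and it shows that this single fluoro leaves compound 3 indistinguishable from compound 1 in this test: the short half-life of compound 1 is still there after the edit. No measurement on hand bears on why the number holds steady across this swap.

One step at one position says nothing about how other groups would behave on the same aromatic carbon, such as a chloro, a methoxy or a nitrile, or about whether a trifluoromethyl in place of the methyl group would give a number beyond the scatter. It also leaves open whether fluoro on another carbon of this ring, or the same swap on a different compound, would give a similar result.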